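The source may report more compounds than this note shows. Statements on the series, on what has been measured and on what is new or still open speak of the compounds shown alone.

Working notes on the series. In an ADME assay on Huh-7 cells (Homo sapiens) for cytotoxicity (a higher number here means that more compound is tolerated, a lower number that less compound is tolerated), compound 1 `CN1CCN(CCCNCc2cn(-c3ccc([N+](=O)[O-])cc3)nc2-c2ccc(OC(F)(F)F)cc2)CC1` gives 1600 nM. For compound 2 `CN1CCN(CCNCc2cn(-c3ccc(F)cc3F)nc2Cc2ccccc2)CC1` this assay records only a limit, > 20000 nM. Compound 3 `Cc1ccccc1-c1nn(Cc2ccc(F)cc2)cc1CNCCN1CCN(C)CC1` likewise stands at a limit in this assay, > 20000 nM, so no number is known for it, only that it sits at the limit of > 20000 nM in this assay, at which 2 of the 3 values shown sit. Among the compounds with values here, no single-change step between measured compounds is available; compound 1 and compound 3 differ in several places at once, and their two values show only that one is a number and the other a limit.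

Compound 4 `Cc1ccccc1-c1nn(-c2ccc(F)c(F)c2)cc1CNCCN1CCN(C)CC1` is not yet measured. It differs from compound 3 by 3,4-difluorophenyl in place of 4-fluorobenzyl on an aromatic nitrogen. Compound 1 and compound 2 both carry an aryl group directly on an aromatic nitrogen of the shared core, and their values fall on either side of the gap between a number and the limit, so this kind of change gives no clear direction on its own. The expected step in this assay is therefore small, an at least 1.3-fold lower number from compound 3 to compound 4 (0.12 log units; that floor lies within the scatter), most likely none beyond the scatter. Compound 4 is estimated at 15000 nM, within 5000 nM to 40000 nM, with a fair chance that this assay again reports only a limit.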

Compound 4, half-maximal cytotoxic concentration: > 20000 nM
Compound 4 ended at the assay's limit; the forecaster's own chance of this, stated with the estimate: 60%; at least 1.3-fold (0.12 log units) between middle value and limit.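

Within the data shown here, compound 4 also stands at a limit in this assay, > 20000 nM, as compound 3 does, so no step between compound 3 and compound 4 can be read. The compounds shown leave open whether 3,4-difluorophenyl in place of 4-fluorobenzyl changes tolerance at all, with most values sitting at: the limit of > 20000 nM in this assay, at which 3 of the 4 values shown sit.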